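The compounds below may be only part of what the source reports. "The series", "measured", "known", "first", "only" and "open" are said of these compounds alone.

Measured compounds:
Compound 1, `COc1ccc(-c2cc(/C=C/C(=O)c3ccc(N)cc3)[nH]n2)cc1`, gives 92% in a functional assay on NCI-H460 cells (Homo sapiens) for cytotoxicity, read by sulforhodamine B assay, with a stated time of 48 h, tested at 1 uM; a lower number here means a stronger effect, a higher number a weaker effect of the compound at the concentration tested.
Compound 2, `COc1ccc(C(=O)/C=C/c2cc(-c3cc(OC)c(OC)c(OC)c3)n[nH]2)cc1OC`, gives 70% in this assay.
Compound 3, `COc1ccc(-c2cc(/C=C/C(=O)c3ccc(N)cc3)[nH]n2)cc1OC`, gives 94% in this assay.

Compound 1 and compound 3 differ in a single place, (methoxy in place of hydrogen on an aromatic carbon). The step measured for this change, a number 2 percentage points higher from compound 1 to compound 3 (within the scatter), shows that the two values cannot be told apart. Compound 2 rests on a different core; how the core of compound 2 differs from that of compound 1 is not broken down here. In this assay compound 2 has the lowest of the three numbers, and both compound 1 and compound 3 stand beyond the scatter above it.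

Compound 4, `COc1cc(C(=O)/C=C/c2cc(-c3cc(OC)c(OC)c(OC)c3)n[nH]2)cc(OC)c1OC`, has not yet been measured. It derives from compound 2 by methoxy in place of hydrogen on an aromatic carbon. This is the same kind of change as that from compound 1 to compound 3, though not the same: around the place, the entering methoxy of compound 4 is also meta to a methoxy group, which is not said of the place in compound 3. Because the step of a number 2 percentage points higher from compound 1 to compound 3 (within the scatter) lay within the scatter, the step expected for compound 4 is a number 4 percentage points higher from compound 2 to compound 4 (within the scatter). In this assay compound 4 is therefore estimated at 74%, with the expected range running from 58% to 90%.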

Compound 4, a percentage reported as activity, at one concentration (the size of the read-out at that concentration, not a potency): 89%
Beside the measured number, compound 4's estimate is 15 percentage points below it; measured number inside the range.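

In this assay the replacement of hydrogen by methoxy on an aromatic carbon did not carry over from one core to the other as a step of one size: the same change on two cores in this assay, a number 2 percentage points higher (within the scatter) from compound 1 to compound 3 and a number 19 percentage points higher (beyond the scatter) from compound 2 to compound 4, 17 percentage points apart, beyond the scatter of two such steps. Among the compounds shown here, on the core of compound 2 the change therefore counts as a real loss of effect at the concentration tested, with a number 19 percentage points higher from compound 2 to compound 4 (beyond the scatter) as its size, while on the core of compound 1 it gave no step that can be told from the scatter, so a step read on one core could not simply be transferred to the other. What this does not show is the reason for the gap, since the two pairs differ in their cores and also around the place itself, where the entering methoxy of compound 4 is meta to a methoxy group, which is not said of the place in compound 3, and two pairs at a single concentration cannot separate these differences.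

The compounds shown leave open how the core of compound 2 would respond to a different group at this place, such as a hydroxyl group, a chlorine atom or an ethoxy group. They also leave open whether a further core would follow compound 1 and compound 3 or compound 2 and compound 4 under the same change.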